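Series notes: a dichlorobenzyl exchange on two cores

This account rests on a few compounds, and the source may have more. Where it says the series, first, only, none or still open, it means among the compounds named here.

Measured so far in a functional assay on MGC-803 cells (Homo sapiens) for inhibition, read by MTT assay, with a stated time of 48 h; a lower number here means a stronger inhibitor, a higher number a weaker inhibitor:
compound 1, `Cc1ccc(NC(=S)NC(=O)c2ccc(OCc3ccccc3Cl)cc2)cc1-c1nc2ccccc2[nH]1`: 45000 nM
compound 2, `Cc1ccc(NC(=S)NC(=O)c2ccc(OCc3ccc(Cl)c(Cl)c3)cc2)cc1-c1nc2ccccc2[nH]1`: 6390 nM
compound 3, `Cc1ccc(NC(=O)NC(=O)c2ccc(OCc3ccccc3Cl)cc2)cc1-c1nc2ccccc2[nH]1`: 19500 nM

Compound 1 and compound 2 share one core and differ in a single place: 3,4-dichlorophenyl in place of 2-chlorophenyl on a saturated chain carbon bound to an oxygen on an aromatic ring. In this assay this exchange gives a 7.0-fold lower number from compound 1 to compound 2 (0.85 log units; beyond the scatter), a step beyond the scatter. Compound 3 carries a second core; the difference between the core of compound 1 and the core of compound 3 is not broken down here. In this assay compound 3 stands second highest of the three numbers, between compound 1 and compound 2, and both gaps to it lie beyond the scatter.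

Compound 4, `Cc1ccc(NC(=O)NC(=O)c2ccc(OCc3ccc(Cl)c(Cl)c3)cc2)cc1-c1nc2ccccc2[nH]1`, has not yet been measured. It differs from compound 3 in one place: 3,4-dichlorophenyl in place of 2-chlorophenyl on a saturated chain carbon bound to an oxygen on an aromatic ring. The place is described in the same words for both pairs, so this is the same change as the one made from compound 1 to compound 2, here carried onto the core of compound 3; among the compounds shown it occurs in two pairs. Within the data shown here, the step from compound 3 to compound 4 in this assay is expected to be about a 5.6-fold lower number from compound 3 to compound 4 (0.75 log units; beyond the scatter), set beside the single measured example a 7.0-fold lower number from compound 1 to compound 2 (0.85 log units; beyond the scatter) and taken somewhat smaller, since one pair on a different core is thin support. Compound 4 is therefore estimated at 3500 nM, with a likely range from 1200 nM to 10000 nM.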

Compound 4, half-maximal inhibitory concentration: 6080 nM
Estimate against measurement, compound 4: 1.7-fold (0.24 log units) below, and the stated range covers the measured number.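

In this assay the exchange of 2-chlorobenzyl for 3,4-dichlorobenzyl, already seen on the core of compound 1, also gives a 3.2-fold lower number from compound 3 to compound 4 (0.51 log units; beyond the scatter) on the core of compound 3, so the direction of the step is the same on both cores shown. The two steps do not differ in size by more than the scatter allows, so they can be read as one effect carried from one core to the other: the same change on two cores in this assay, a 7.0-fold lower number (0.85 log units; beyond the scatter) from compound 1 to compound 2 and a 3.2-fold lower number (0.51 log units; beyond the scatter) from compound 3 to compound 4, 2.2-fold (0.34 log units) apart, within the scatter of two such steps. Among these compounds, this rests on only two pairs, and it shows neither that the exchange would carry onto any further core nor what lies behind the lower numbers of the 3,4-dichlorobenzyl compounds.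

The compounds shown do not separate the added chlorine from the change in where the chlorines stand, and an unsubstituted benzyl group or a benzyl ring bearing fluorine or methoxy would be needed to place the exchange within a wider set of groups. Also open, from the compounds shown here alone, is whether the same exchange holds with an amine in place of the oxygen that links the saturated chain carbon to the aromatic ring.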